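A few compounds are considered here, and "the series" means these few. Any claim that something is new, unique, unknown or untested is made for them only; others in the source may bear on it.

Compound 2 `Cn1c(N2CCCC2)c(C#N)c2c(N)ncnc21` is the simplest of the three measured compounds: it carries the shared core with a pyrrolidin-1-yl group and a nitrile, but lacks the pyrazole-bearing amine seen in the others. In an assay on isolated protein for inhibition of Leucine-rich repeat serine/threonine-protein kinase 2 variant G2019S (Homo sapiens), read by TR-FRET and LanthaScreen, with stated times of 50 min and 30 min, in the presence of a further agent that is not named here (a higher number here means a weaker inhibitor, a lower number a stronger inhibitor), compound 2 gives 1910 nM, the highest number of the three and therefore the weakest inhibitor here. For the measured compounds named here, compound 1 `C[C@@H]1CCCN1c1c(C#N)c2c(N)nc(Nc3cn[nH]c3)nc2n1C` gives 6 nM, and compound 3 `Cc1c(Nc2nc(N)c3c(C#N)c(N4CCC[C@H]4C)n(C)c3n2)cnn1C1COC1` gives 37 nM; the only one-point step among them, a 6.2-fold higher number from compound 1 to compound 3 (0.79 log units; beyond the scatter), changes the pyrazole substitution and says nothing about the pyrrolidine side of the core.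

Compound 4 `Cn1c(-c2ccccc2)c(C#N)c2c(N)ncnc21` differs from compound 2 in exactly that other place: phenyl in place of pyrrolidin-1-yl on an aromatic carbon. Going by the values given here, no measured pair shows this exchange, and the two compounds that carry the pyrrolidine in a potent setting, compound 1 and compound 3, also carry the pyrazole amine, so they cannot separate the two contributions. Among the compounds with values here, with no step bearing directly on the change, the expectation for compound 4 in this assay rests on compound 2 alone and is wide. Compound 4 is estimated at 3000 nM, within a range from 700 nM to 13000 nM, meaning an expected step of a 1.6-fold higher number from compound 2 to compound 4 (0.20 log units; within the scatter), in either direction not clearly beyond the scatter.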

Compound 4, half-maximal inhibitory concentration: 483 nM
Compound 4: middle estimate off by 6.2-fold (0.79 log units), on the high side, and the stated range ends above it.
By their numbers in this assay, from the lowest: compound 1; then compound 3; then compound 4; then compound 2.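

At this aromatic carbon of the five-membered aromatic ring, phenyl in place of pyrrolidin-1-yl gives a stronger inhibitor in this assay, with a step of a 4.0-fold lower number from compound 2 to compound 4 (0.60 log units; beyond the scatter) that lies beyond the usual scatter. For the compounds shown here, this is the first direct reading of this position, since the earlier step changed only the group on the pyrazole side of the molecule; it shows that the saturated nitrogen-bearing ring is not required for binding in this simple setting, and that an all-carbon aromatic ring can take its place and do better. No measurement shown here explains why the number falls.

On these data alone, the phenyl group appears only on the simplest form of the shared core, so it remains open whether the same gain would appear in compounds that also carry the pyrazole-bearing amine, such as compound 1 and compound 3. Also open, as far as these compounds go, is how other groups on this carbon would compare, for example a morpholine ring, a pyridine ring, or a phenyl ring carrying a fluorine atom.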